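Branched Secondary Amine in Place of a Tertiary Amine

The compounds below may be only part of what the source reports. "The series", "measured", "known", "first", "only" and "open" are said of these compounds alone.

Measured so far:
compound 1, `CCC(COC)Nc1nc(C)nc2c(-c3ccc(Cl)cc3Cl)c(C)nn12`: 1.9 nM
compound 2, `CCCCN(CC)c1nc(C)nc2c(-c3ccc(Cl)cc3Cl)c(C)nn12`: 0.4 nM

Both compounds were tested in an assay on isolated protein for displacement of a labelled ligand from corticotropin-releasing factor receptor 1 (Homo sapiens); on this read-out lower numbers stand for stronger inhibition and higher numbers for weaker inhibition. Among the compounds with values here, compound 1 gives 1.9 nM and compound 2 gives 0.4 nM, so compound 2 has the lower of the two numbers, and the one step measured, a 4.8-fold lower number from compound 1 to compound 2 (0.68 log units; beyond the scatter), lies beyond the scatter.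

Compound 3, `CCCC(CCC)Nc1nc(C)nc2c(-c3ccc(Cl)cc3Cl)c(C)nn12`, has not yet been measured. It differs from compound 2 in one place: (1-propylbutyl)amino in place of butyl(ethyl)amino on an aromatic carbon. The amine that enters carries a hydrogen, as in compound 1, and its two propyl chains make it larger than the group that leaves.

Within the data shown here, only one measured step bears on this change, and it goes the other way: a 4.8-fold lower number from compound 1 to compound 2 (0.68 log units; beyond the scatter) shows that, on the shared core, moving from a hydrogen-bearing amine to a fully substituted one lowered the number modestly. Compound 3 returns to a hydrogen-bearing amine, but with a different branched chain, so the step is expected to be small and, if anything, toward a higher number: a 2.0-fold higher number from compound 2 to compound 3 (0.30 log units; within the scatter). Compound 3 is therefore estimated at 0.8 nM, with a range from 0.3 nM to 3 nM.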

Compound 3, inhibition constant: 1.6 nM
Compound 3: the middle estimate sits 2.0-fold (0.30 log units) below what was measured; the range from low to high includes it.
By their numbers in this assay, from the lowest: compound 2; then compounds 3 and 1 (each within the scatter of the next).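

In this assay, (1-propylbutyl)amino in place of butyl(ethyl)amino gives a 4.0-fold higher number from compound 2 to compound 3 (0.60 log units; beyond the scatter) on the shared core, so this second amine bearing a hydrogen also sits on the higher side of the fully substituted amine of compound 2. Changing the chain on the nitrogen from 1-(methoxymethyl)propyl to 1-propylbutyl gives a 1.2-fold lower number from compound 1 to compound 3 (0.07 log units; within the scatter) and therefore no difference that can be read, even though the methoxymethyl arm is replaced by a plain propyl chain. Across these three compounds, both amines with a hydrogen on the nitrogen stand apart from compound 2 by more than the scatter, and neither goes against that pattern.

The data offer no explanation for this gap. On these data alone, it remains open whether the lower number follows the missing hydrogen on the nitrogen or the particular butyl and ethyl chains, and a dipropylamino group or a pyrrolidine ring on the same aromatic carbon would help separate the two.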